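Adding a Second Methyl to Compound 2

This account rests on a few compounds, and the source may have more. Where it says the series, first, only, none or still open, it means among the compounds named here.

Compound 1, `CCCc1nc(-c2ccccc2)c(CNCCCN2CCN(c3ccc(C(F)(F)F)cc3)CC2)o1`, gives 51.6% in an assay on HEK293 cells for inhibition of Voltage-dependent T-type calcium channel subunit alpha-1G (Homo sapiens), read by fluorescence, tested at 10 uM; a lower number here means less inhibition, a higher number more inhibition at the concentration tested (going by the name of the read-out).
Compound 2, `CCCc1nc(-c2ccccc2)c(CNCCCN2CCN(c3cccc(C)c3)CC2)o1`, gives 47.8% in this assay.

For the measured compounds named here, only two compounds have been measured in this assay, and they are joined by a single step, a number 3.8 percentage points lower from compound 1 to compound 2 (within the scatter). That change swaps the whole aromatic group on the amine nitrogen in the ring, yet the read-out barely moves; compound 2 therefore stands within the scatter of compound 1, and the two numbers cannot be told apart.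

Compound 3, `CCCc1nc(-c2ccccc2)c(CNCCCN2CCN(c3ccc(C)c(C)c3)CC2)o1`, is not yet measured. It differs from compound 2 in one place: methyl in place of hydrogen on an aromatic carbon. Read one bond further out, the change is 3-methylphenyl to 3,4-dimethylphenyl. Going by the values given here, no measured step adds a methyl to this ring, so the only step that bears on the question is the one from compound 1 to compound 2, which was a number 3.8 percentage points lower from compound 1 to compound 2 (within the scatter). Since a far larger swap on the same nitrogen left the number within the scatter, compound 3 is expected to sit close to compound 2, with a step of a number 1.2 percentage points higher from compound 2 to compound 3 (within the scatter), essentially none beyond the scatter. Compound 3 is thus estimated at 49%, with a range from 30% to 66%.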

Compound 3, a percentage reported as inhibition, at one concentration (the size of the read-out at that concentration, not a potency): 54.6%
Beside the measured number, compound 3's estimate is 5.6 percentage points below it, and the stated range covers the measured number.
By their numbers in this assay, from the lowest: compounds 2, 1 and 3 (each within the scatter of the next).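

In this assay, for the compounds shown here, this is the first reading of methyl in place of hydrogen on this aromatic ring, at the carbon ortho to a methyl group and para to a large group, and the added methyl leaves the two compounds within the scatter (a number 6.8 percentage points higher from compound 2 to compound 3 (within the scatter)). The 3,4-dimethylphenyl group also cannot be told apart from the 4-(trifluoromethyl)phenyl group on the same ring nitrogen (a number 3 percentage points higher from compound 1 to compound 3 (within the scatter)), so the three aromatic groups shown on this nitrogen give numbers that all lie within the scatter of one another, and neither a second methyl nor a trifluoromethyl group separates any compound from the others. No measurement is available that could explain these readings.

The compounds shown leave open whether a group of another kind on this aromatic ring, such as a carboxylic acid or an amine, would give a number beyond the scatter, and whether a longer chain in place of the propyl chain on the shared core would do so. Since each compound was read at one concentration only, these numbers also leave the potencies of all three compounds open.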